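Swapping the Amide Aryl Ring: Compound 2 to Compound 3

This account rests on a few compounds, and the source may have more. Where it says the series, first, only, none or still open, it means among the compounds named here.

Two measured compounds share one core and differ only in the ring on an amide-type nitrogen. Compound 1 `COc1ccc(NC(=O)c2nc(-c3cc(OC)c(OC)c(OC)c3)n(-c3ccc(OC)cc3)n2)cc1` gives 63% in a functional assay on the whole organism for inhibition, with Rattus norvegicus as the target, read by paw edema, with stated times of 30 min and 4 h, at a dose of 0.28 mmol/kg by the oral route; a lower number here means less inhibition, a higher number more inhibition at the dose given (going by the name of the read-out). Compound 2 `COc1ccc(-n2nc(C(=O)Nc3ccccc3C)nc2-c2cc(OC)c(OC)c(OC)c2)cc1` gives 46% in this assay, the lower of the two numbers, the change being a number 17 percentage points lower from compound 1 to compound 2 (beyond the scatter). Compound 3 `COc1ccc(-n2nc(C(=O)Nc3cccc(F)c3)nc2-c2cc(OC)c(OC)c(OC)c2)cc1` carries yet another ring at that place: 3-fluorophenyl in place of 2-methylphenyl on an amide-type nitrogen. Among the compounds with values here, no measured step covers this particular exchange; the single known step concerns a different ring and bears on it only loosely. Only a small step is therefore expected, a number 6 percentage points higher from compound 2 to compound 3 (within the scatter), with no clear direction. Compound 3 is estimated at 52%, between 32% and 70%.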

Compound 3, a percentage reported as inhibition, in the whole organism at one dose (the size of the read-out at that dose, not a potency): 70%
For compound 3 the middle estimate is 18 percentage points below the measured one; low and high end bracket the measured number.
By their numbers in this assay, from the lowest: compound 2; then compounds 1 and 3 (each within the scatter of the next).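

In this assay this place on the amide-type nitrogen moves the number both ways: 3-fluorophenyl in place of 2-methylphenyl gives a number 24 percentage points higher from compound 2 to compound 3 (beyond the scatter) and so undoes the earlier drop. Against 4-methoxyphenyl, the same ring gives a number 7 percentage points higher from compound 1 to compound 3 (within the scatter) so two differently substituted rings read alike here, and only 2-methylphenyl stands apart. Nothing available explains this difference.

From the compounds shown here alone, whether the low number belongs to the methyl group itself or to where it sits on the ring stays open. So does how a ring carrying an amine or a carboxylic acid, or a longer chain in place of the ring, would read out.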